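Chloro step from compound 2 to compound 3

The compounds below may be only part of what the source reports. "The series", "measured", "known", "first", "only" and "open" are said of these compounds alone.

Compound 1 `O=c1sc2cc(Nc3ncnc4c3cnn4-c3ccc(Cl)cc3)ccc2n1Cc1ccc(Cl)cc1Cl`: > 100000 nM
Compound 2 `Clc1ccc2nc(Nc3ncnc4c3cnn4-c3ccccc3)sc2c1`: > 100000 nM

In a functional assay on MCF7 cells (Homo sapiens) for cytotoxicity, read by sulforhodamine B assay, with a stated time of 72 h (on this read-out higher numbers stand for weaker inhibition and lower numbers for stronger inhibition), compound 2 gives > 100000 nM, which is a limit and not a number. Among the measured compounds shown here, the series so far stands at the limit of > 100000 nM in this assay, at which 2 of the 2 values shown sit. Compound 3 `Clc1ccc(-n2ncc3c(Nc4nc5ccc(Cl)cc5s4)ncnc32)cc1` differs from compound 2 by chloro in place of hydrogen on an aromatic carbon, phenyl to 4-chlorophenyl: chloro in place of hydrogen on an aromatic carbon. Compound 1, which also carries a 4-chlorophenyl, gives > 100000 nM, also a limit. No step beyond the scatter is expected in this assay, and no direction is favoured. The estimated step of a number no higher from compound 2 to compound 3 (the limit leaves the size open) is correspondingly small. Compound 3 is expected at 100000 nM, within an estimated range of 40000 nM to 200000 nM.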

Compound 3, half-maximal inhibitory concentration: 85600 nM
Estimate against measurement, compound 3: 1.2-fold (0.07 log units) above; the range from low to high includes it.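

In this assay, among the compounds shown here, 4-chlorophenyl in place of phenyl yields the first reading that is a number and not a limit: compound 3 gives 85600 nM. The change at this position, para to a large group, amounts to an at least 1.1-fold lower number from compound 2 to compound 3 (0.06 log units; that floor lies within the scatter), so chloro here has not been shown to do more than the scatter allows. The other readings remain limits: the limit of > 100000 nM in this assay, at which 2 of the 3 values shown sit.

As far as these compounds go, whether an amine or a carboxylic acid at this position would move the value beyond the scatter stays open. Compound 1 differs from compound 3 in more than one place and cannot settle the size of the chloro step.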